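The source may hold more compounds than are shown below. What is called first, only, known or untested is meant among the compounds shown, and "the series" means these compounds.

Compound 1, `CC(=O)C1=C(C)NC(=O)NC1c1ccsc1`, gives 24% in an assay on membranes from HEK293 cells for displacement of a labelled ligand from adenosine receptor A2b (Homo sapiens), read by scintillation counting, with a stated time of 30 min, tested at 1 uM; a lower number here means less inhibition, a higher number more inhibition at the concentration tested (going by the name of the read-out).
Compound 2, `CC1=C(C(=O)C2CC2)C(c2ccsc2)NC(=O)N1`, gives 1%.
Compound 3, `CCNC(=O)C1=C(C)NC(=O)NC1c1ccsc1`, gives 1%.

All three share one core and differ only in the group on the carbonyl carbon. For the measured compounds named here, compound 3 stands level with compound 2, and together they are the lowest of the three numbers; the one step beyond the scatter is a number 23 percentage points lower from compound 1 to compound 3 (beyond the scatter), while no change at the digits printed from compound 2 to compound 3 (within the scatter) shows that swapping ethylamino for cyclopropyl made no difference.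

Compound 4, `CC1=C(C(=O)NC(C)C)C(c2ccsc2)NC(=O)N1`, is the next compound. It differs from compound 3 by methyl in place of hydrogen on a saturated chain carbon bound to an amide-type nitrogen and a saturated chain carbon.

Going by the values given here, no measured pair shows exactly this change. The measured steps concern the group placed directly on the carbonyl carbon, and two of the three such groups, in compound 2 and compound 3, already sit at the bottom of the range. Adding one carbon further out on the ethylamino chain is a smaller alteration than any of those, so the expectation for compound 4 is a step of about a number 1 percentage points higher from compound 3 to compound 4 (within the scatter), that is, none beyond the scatter. Compound 4 is therefore estimated at 2%, with a range from -8% to 12%.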

Compound 4, a percentage reported as inhibition, at one concentration (the size of the read-out at that concentration, not a potency): 3%
The estimate for compound 4 lay 1 percentage points below the measured number, within the range that was stated.
By their numbers in this assay, from the lowest: compounds 2, 3 and 4 (each within the scatter of the next); then compound 1.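

Moving the change one carbon further out, from ethylamino to isopropylamino, gives a number 2 percentage points higher from compound 3 to compound 4 (within the scatter) in this assay, so methyl in place of hydrogen on this saturated chain carbon does not lift the amide series away from the bottom of the range. Compared directly on the carbonyl carbon, isopropylamino and cyclopropyl give a number 2 percentage points higher from compound 2 to compound 4 (within the scatter), while isopropylamino and methyl give a number 21 percentage points lower from compound 1 to compound 4 (beyond the scatter), which leaves compound 1, with its methyl group, as the only one of the four set apart from the rest. No evidence is available that explains these numbers.

The compounds shown leave open whether a longer chain on the amide nitrogen, such as n-butyl, or a phenyl ring in that place would give a number beyond the scatter of compound 3. Going by these compounds, it also remains open how ethyl on the carbonyl carbon, a group one carbon longer than the methyl of compound 1, would read in this assay.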